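Removing a Methyl from the Aryl Amide Oxygen

The source may hold more compounds than are shown below. What is called first, only, known or untested is meant among the compounds shown, and "the series" means these compounds.

Compound 1, `COc1ccc(NC(=O)[C@@H]2CC=C(CCC=C(C)C)C[C@H]2c2ccccc2)cc1`: in an assay on isolated protein for inhibition of Apoptosis regulator Bcl-2 (Homo sapiens), read by fluorescence polarization, with stated times of 5 min and 10 min (a higher number here means a weaker inhibitor, a lower number a stronger inhibitor), compound 1 gives > 23000 nM, which is a limit of the assay and not a number.
Compound 2, `CC(C)=CCCC1=CC[C@H](C(=O)N(C)O)[C@@H](c2ccccc2)C1`: in this assay compound 2 gives 2100 nM.
Compound 3, `CC(C)=CCCC1=CC[C@@H](C(=O)N(C)C)[C@H](c2ccccc2)C1`: in this assay compound 3 gives > 23000 nM, again a limit of the assay.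

Compound 1 stands at a limit (the limit of > 23000 nM in this assay, at which 2 of the 3 values shown sit), so its true potency is only known to be weak. Among the compounds with values here, the one measured step, a step that the two limits leave unreadable from compound 1 to compound 3, runs between two limits and is unreadable in size, and it changes the amide nitrogen, not the aromatic oxygen. Compound 4, `CC(C)=CCCC1=CC[C@@H](C(=O)Nc2ccc(O)cc2)[C@H](c2ccccc2)C1`, is not yet measured. It differs from compound 1 by hydrogen in place of methyl on an oxygen on an aromatic ring. Within the data shown here, no measured step bears on that change, and compound 1 gives no number to move from, so no size or direction can be read for the step to compound 4. The expectation is therefore that compound 4 stays weak, with an estimated step of an at least 1.1-fold lower number from compound 1 to compound 4 (0.06 log units; that floor lies within the scatter). For compound 4 the estimated value is 20000 nM, within 5000 nM to 60000 nM.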

Compound 4, inhibition constant: > 23000 nM
Compound 4: a limit, no number (the forecaster's own chance of this, stated with the estimate: 60%); at least 1.1-fold (0.06 log units) between middle value and limit.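

Compound 4 gives a limit of the assay and not a number, as do compound 1 and compound 3, so no step among these three can be read: the limit of > 23000 nM in this assay, at which 3 of the 4 values shown sit.

The compounds shown leave open whether hydroxy and methoxy differ at all in this assay on this shared core.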